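This account rests on a few compounds, and the source may have more. Where it says the series, first, only, none or still open, it means among the compounds named here.

Measured compounds:
compound 1 `CC(=O)OC[C@H]1O[C@@H](n2cc(CN3C(=O)/C(=C\c4ccccc4)c4ccccc43)nn2)[C@H](OC(C)=O)[C@@H](OC(C)=O)[C@@H]1OC(C)=O` — in a functional assay on HeLa cells (Homo sapiens) for cytotoxicity, read by sulforhodamine B assay, with a stated time of 48 h (a lower number here means a stronger inhibitor, a higher number a weaker inhibitor), compound 1 gives 33300 nM
compound 2 `CC(=O)OC[C@H]1O[C@@H](n2cc(CN3C(=O)/C(=C\C=C\c4ccccc4)c4ccccc43)nn2)[C@H](OC(C)=O)[C@@H](OC(C)=O)[C@@H]1OC(C)=O` — in this assay compound 2 gives 98100 nM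
compound 3 `CCC/C=C1/C(=O)N(Cc2cn([C@@H]3O[C@H](COC(C)=O)[C@@H](OC(C)=O)[C@H](OC(C)=O)[C@H]3OC(C)=O)nn2)c2ccccc21` — in this assay compound 3 gives > 100000 nM, which is a limit of the assay and not a number

Compound 3 thus stands at the limit of > 100000 nM in this assay, at which 1 of the 3 values shown sits, the weakest reading the assay can report. Compound 4 `CCC/C=C1\C(=O)N(Cc2cn([C@@H]3O[C@H](COC(C)=O)[C@@H](OC(C)=O)[C@H](OC(C)=O)[C@H]3OC(C)=O)nn2)c2ccccc21` differs from it only in configuration: the two compounds have the same atoms and bonds and differ only in configuration as drawn: 1 of 6 stereo elements differ; a double bond is drawn E in compound 3 and Z in compound 4. Going by the values given here, the one measured step, a 2.9-fold higher number from compound 1 to compound 2 (0.47 log units; beyond the scatter), changed the group on the double-bonded chain carbon rather than its geometry, so it offers no direct guide to an E-to-Z change. With compound 3 already at the limit, compound 4 is expected to sit near the same region, and the step of an at least 1.1-fold lower number from compound 3 to compound 4 (0.04 log units; that floor lies within the scatter) is expected to be small. The estimate for compound 4 is 90000 nM, in a range from 30000 nM to 200000 nM.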

Compound 4, half-maximal inhibitory concentration: 46300 nM
Compound 4: middle estimate off by 1.9-fold (0.29 log units), on the high side; the measured number falls inside the stated range.
By their numbers in this assay, from the lowest: compounds 1 and 4 (each within the scatter of the next); then compound 2. At a limit, above all of these: compound 3.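

The geometry of this double bond counts in this assay: the E-to-Z change gives an at least 2.1-fold lower number from compound 3 to compound 4 (0.33 log units; beyond the scatter), and the step can be laid to geometry alone because of this: the fact that compounds 3 and 4 differ only in the configuration as drawn. Compound 3 reads > 100000 nM, which is a limit and not a number. Propyl in place of 2-phenylethenyl gives a 2.1-fold lower number from compound 2 to compound 4 (0.33 log units; beyond the scatter), while propyl in place of phenyl gives a 1.4-fold higher number from compound 1 to compound 4 (0.14 log units; within the scatter), so propyl and phenyl cannot be told apart here.

From the compounds shown here alone, whether flipping the double bond changes the reading when phenyl or 2-phenylethenyl sits on this carbon remains open. So does what a longer chain such as hexyl, or a chain ending in an amine, would give.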